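Urea series on the shared core: outlook for compound 4

This account rests on a few compounds, and the source may have more. Where it says the series, first, only, none or still open, it means among the compounds named here.

Three ureas on the shared core have been measured in a functional assay on GBM3 cells (Homo sapiens) for antiproliferative activity, read by WST assay, with a stated time of 72 h; a higher number here means a weaker inhibitor, a lower number a stronger inhibitor. Compound 2 `O=C(Nc1ccccc1F)Nc1cc2ncncc2cc1OCc1ccccc1F` gives 3800 nM, the lowest of the three numbers. Compound 3 `O=C(Nc1cccc(Cl)c1)Nc1cc2ncncc2cc1OCc1ccccc1` gives 6400 nM, within the scatter of compound 2, so no order is read between these two. Compound 1 `O=C(Nc1cccc(F)c1)Nc1cc2ncncc2cc1OCc1cccc(Cl)c1` gives 8300 nM, a gap from compound 2 that lies beyond the scatter. Compound 4 `O=C(Nc1ccc(Cl)c(Cl)c1)Nc1cc2ncncc2cc1OCc1ccccc1F` is not yet measured; it differs from compound 2 as follows: 3,4-dichlorophenyl in place of 2-fluorophenyl on an amide-type nitrogen. Within the data shown here, no measured pair shows this change, so its size is unknown, and the spread among the three measured compounds is modest. The expected step is small, likely within the scatter: a 1.3-fold lower number from compound 2 to compound 4 (0.10 log units; within the scatter). Compound 4 is accordingly expected near 3000 nM, in a range from 1200 nM to 8000 nM.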

Compound 4, half-maximal inhibitory concentration: > 10000 nM
Compound 4: a limit, no number (the forecaster's own chance of this, stated with the estimate: 3%); at least 3.3-fold (0.52 log units) between middle value and limit.
By their numbers in this assay, from the lowest: compounds 2, 3 and 1 (each within the scatter of the next, the first and the last beyond it). At a limit, above all of these: compound 4.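

In this assay, 3,4-dichlorophenyl in place of 2-fluorophenyl on an amide-type nitrogen gives an at least 2.6-fold higher number from compound 2 to compound 4 (0.42 log units; beyond the scatter), so the series does respond to the group at this place. Among these compounds, this is the first single-place step that can be read. Its lower bound rests on a limit of the assay, not a number, and its full size stays unknown: the limit of > 10000 nM in this assay, at which 1 of the 4 values shown sits.

The compounds shown do not separate the effect of adding the two chlorines from that of removing the fluorine. Going by these compounds, how a cyclohexyl or pyridyl group on this nitrogen would read also stays open.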